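Halogen swap at the varied carbon of the shared core

This account rests on a few compounds, and the source may have more. Where it says the series, first, only, none or still open, it means among the compounds named here.

In an ADME assay on L1210/0 cells (Mus musculus) for cytotoxicity, with a stated time of 48 h (a lower number here means a stronger inhibitor, a higher number a weaker inhibitor), compound 1 `Nc1nc2c(nc(N)n2COCCO)c(=O)[nH]1` gives only a limit, > 200000 nM. Compound 2 `CN(C)c1nc2c(=O)[nH]c(N)nc2n1COCCO` likewise reaches only a limit, > 200000 nM. Compound 3 `Nc1nc2c(nc(Br)n2COCCO)c(=O)[nH]1` also stops at a limit, > 200000 nM. The three steps, a step that the two limits leave unreadable from compound 1 to compound 2, a step that the two limits leave unreadable from compound 1 to compound 3 and a step that the two limits leave unreadable from compound 2 to compound 3, cannot be sized because of the limit of > 200000 nM in this assay, at which 3 of the 3 values shown sit. Compound 4 `Nc1nc2c(nc(Cl)n2COCCO)c(=O)[nH]1` differs from compound 3 by chloro in place of bromo on an aromatic carbon. No measured step bears on this exchange, and none of the shown steps is readable, so nothing in the series points to a change beyond the scatter. The step from compound 3 to compound 4 is therefore estimated as a number no higher from compound 3 to compound 4 (the limit leaves the size open). Compound 4 is expected to sit again at the limit, estimated at 200000 nM with a range from 100000 nM to 400000 nM.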

Compound 4, half-maximal inhibitory concentration: > 200000 nM
Compound 4: a limit, no number (the forecaster's own chance of this, stated with the estimate: 85%); the middle value lies on the limit itself.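

No step from compound 1, compound 2 or compound 3 to compound 4 can be read, because each value is only a limit: the limit of > 200000 nM in this assay, at which 4 of the 4 values shown sit.

The compounds shown leave open whether any group at the varied carbon of the shared core gives a readable value.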